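A few compounds are considered here, and "the series" means these few. Any claim that something is new, unique, unknown or untested is made for them only; others in the source may bear on it.

Measured so far:
compound 1 `COc1ncnc2c1c(-c1ccoc1)cn2[C@@H]1O[C@H](CO)[C@@H](O)[C@H]1O` — 1790 nM
compound 2 `CN(C)c1ncnc2c1c(-c1ccoc1)cn2[C@@H]1O[C@H](CO)[C@@H](O)[C@H]1O` — 9060 nM

Compound 2 gives the higher of the two numbers in a functional assay on HeLa S3 cells (Homo sapiens) for antiproliferative activity, read by XTT assay, with a stated time of 72 h (a higher number here means a weaker inhibitor, a lower number a stronger inhibitor), and its nearest neighbour, compound 1, stands at a lower number, the step from one to the other being a 5.1-fold higher number from compound 1 to compound 2 (0.70 log units; beyond the scatter). Compound 3 `Cc1ncnc2c1c(-c1ccoc1)cn2[C@@H]1O[C@H](CO)[C@@H](O)[C@H]1O` has not yet been measured. It differs from compound 2 as follows: methyl in place of dimethylamino on an aromatic carbon. For the measured compounds named here, only one measured step bears on this change, the one in which dimethylamino replaced methoxy on the same aromatic carbon, and it raised the number by a 5.1-fold higher number from compound 1 to compound 2 (0.70 log units; beyond the scatter). Removing dimethylamino again, now for methyl, is therefore expected to reverse at least part of that rise, so the step of a 4.5-fold lower number from compound 2 to compound 3 (0.66 log units; beyond the scatter) is expected to go downward and beyond the scatter. On that basis compound 3 is estimated at 2000 nM, with a likely range from 500 nM to 8000 nM.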

Compound 3, half-maximal inhibitory concentration: > 20000 nM
Compound 3: no number, only a limit; the forecaster's own chance of this, stated with the estimate: 5%; middle value at least 10-fold (1.00 log units) away from the limit.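

In this assay compound 3 gives > 20000 nM, which is a limit of the assay and not a number. Replacing dimethylamino with methyl gives an at least 2.2-fold higher number from compound 2 to compound 3 (0.34 log units; beyond the scatter), and replacing methoxy with methyl gives an at least 11-fold higher number from compound 1 to compound 3 (1.04 log units; beyond the scatter), so on this aromatic carbon, next to the ring nitrogen, methyl does not win back what dimethylamino lost and gives the weakest inhibitor of the three. Fewer heavy atoms on this carbon therefore do not go with a lower number across these compounds, since methyl has the fewest and gives the weakest result.

From the compounds shown here alone, the real size of both steps stays open, as the reading for compound 3 is only a limit: the limit of > 20000 nM in this assay, at which 1 of the 3 values shown sits. Going by these compounds, it is also open whether a plain amine, an ethoxy group or a longer carbon chain on this carbon would sit closer to methoxy or to methyl.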